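This account rests on a few compounds, and the source may have more. Where it says the series, first, only, none or still open, it means among the compounds named here.

Measured so far:
compound 1 `CCCN(CCC)CC(C1CCCCC1)N1CCN(C(=O)[C@@H]2CN(C(C)(C)C)C[C@H]2c2ccc(F)cc2F)CC1` — in an assay on CHO cells for displacement of a labelled ligand from Melanocortin receptor 4 (Homo sapiens) (on this read-out lower numbers stand for stronger inhibition and higher numbers for weaker inhibition), compound 1 gives 200 nM
compound 2 `CC(C)N(CC(C1CCCCC1)N1CCN(C(=O)[C@@H]2CN(C(C)(C)C)C[C@H]2c2ccc(F)cc2F)CC1)S(C)(=O)=O` — in this assay compound 2 gives 13 nM; 15 nM (2 entries)

Within the data shown here, compound 1 is the only compound here with a single number; a further entry of it carries no number at all. Compound 2 shows lower values than compound 1, and the several entries of compound 2 (the several entries of compound 2 in this assay, 13 nM; 15 nM (2 entries)) agree closely with one another, which says the read-out repeats well for this kind of compound.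

Compound 3 `CC(C)NCC(C1CCCCC1)N1CCN(C(=O)[C@@H]2CN(C(C)(C)C)C[C@H]2c2ccc(F)cc2F)CC1` has not yet been measured in this assay. It differs from compound 1 in one place: isopropylamino in place of dipropylamino on a saturated chain carbon, two bonds along the chain from an amine nitrogen in a ring and a saturated ring carbon. Among the measured compounds shown here, no measured pair shows this exact change, so the size of the step can only be guessed from the two numbers at hand. Compound 1 gives 200 nM, and the change to compound 3 keeps the amine but trims it to a smaller group carrying one donor. The step from compound 1 to compound 3 is expected to be a 1.3-fold higher number from compound 1 to compound 3 (0.10 log units; within the scatter), a shift not clearly beyond the usual scatter. Compound 3 is expected to give about 250 nM, with a likely range from 60 nM to 1000 nM.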

Compound 3, half-maximal inhibitory concentration: 310 nM
For compound 3 the middle estimate is 1.2-fold (0.09 log units) below the measured one, within the range that was stated.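

In this assay, replacing dipropylamino with isopropylamino on this saturated chain carbon gives a 1.6-fold higher number from compound 1 to compound 3 (0.19 log units; within the scatter). The group that enters has fewer heavy atoms and brings a hydrogen-bond donor that the departing group lacks, yet the two compounds cannot be told apart on this read-out, so neither the shorter group nor the added donor shows a measurable effect on its own here. Compound 3 also gives the first direct look at the sulfonamide of compound 2, which shares the isopropyl group: compound 3 gives 310 nM and compound 2 gives 13 nM; 15 nM (2 entries), a gap that can be trusted as more than noise, since the read-out repeats well: the several entries of compound 2 in this assay, 13 nM; 15 nM (2 entries)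

The compounds shown leave open whether a secondary amine with a different group, such as ethylamino or cyclopropylamino, would read the same as compound 3. They also leave open whether the low number of compound 2 needs the methylsulfonyl group itself, or whether an acetyl group in its place would do as well.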